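The compounds below may be only part of what the source reports. "The series", "measured", "known", "first", "only" and "open" are said of these compounds alone.

Three members of the series share one core and differ only in the aryl group attached to it. Compound 1 `O=C(O)Cc1sc(C(c2ccc(F)cc2)c2ccc(F)cc2)nc1-c1ccc(Cl)cc1` gives 9.7 nM in an in vitro assay on HEK385-7 cells for displacement of a labelled ligand from prostaglandin D2 receptor 2 (Homo sapiens); on this read-out lower numbers stand for stronger inhibition and higher numbers for weaker inhibition. Compound 2 `O=C(O)Cc1sc(C(c2ccc(F)cc2)c2ccc(F)cc2)nc1-c1ccco1` gives 18 nM in this assay, and compound 3 `O=C(O)Cc1sc(C(c2ccc(F)cc2)c2ccc(F)cc2)nc1-c1ccoc1` gives 14 nM. On these three numbers compound 3 stands second highest, with compound 2 nearest and compound 1 furthest, yet every gap is within the scatter, so no order among the three can be read. The steps of a 1.9-fold higher number from compound 1 to compound 2 (0.27 log units; within the scatter), a 1.4-fold higher number from compound 1 to compound 3 (0.16 log units; within the scatter) and a 1.3-fold lower number from compound 2 to compound 3 (0.11 log units; within the scatter) all remain within the scatter.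

Compound 4 `COc1cc(-c2nc(C(c3ccc(F)cc3)c3ccc(F)cc3)sc2CC(=O)O)ccn1` has not yet been measured in this assay. It is obtained from compound 3 by the change (2-methoxypyridin-4-yl in place of furan-3-yl on an aromatic carbon). The measured steps at this same position, 4-chlorophenyl to furan-2-yl, 4-chlorophenyl to furan-3-yl, and furan-2-yl to furan-3-yl, all stayed within the scatter, which bears directly on the new change; none of them involved a six-membered ring, so that part of the change is not covered by the data. The expectation is therefore a step no larger than the scatter in this assay, a 1.2-fold lower number from compound 3 to compound 4 (0.07 log units; within the scatter), with no preferred direction. Compound 4 is estimated at 12 nM, within 5 nM to 35 nM.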

Compound 4, half-maximal inhibitory concentration: 29 nM
For compound 4 the middle estimate is 2.4-fold (0.38 log units) below the measured one; measured number inside the range.
By their numbers in this assay, from the lowest: compounds 1, 3, 2 and 4 (each within the scatter of the next, the first and the last beyond it).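

Both a 2.1-fold higher number from compound 3 to compound 4 (0.32 log units; beyond the scatter) and a 3.0-fold higher number from compound 1 to compound 4 (0.48 log units; beyond the scatter) lie beyond the scatter in this assay and count as modest, while every earlier step at this position stayed within it, so the aromatic carbon next to the ring nitrogen does not accept every aryl group equally. The separation is only partial: a 1.6-fold higher number from compound 2 to compound 4 (0.21 log units; within the scatter) stays within the scatter, so the 2-methoxypyridin-4-yl group cannot be set apart from the furan-2-yl group, and this first six-membered aromatic ring among the heteroaryl groups differs clearly only from furan-3-yl and 4-chlorophenyl. No measurement at hand bears on why these steps arise.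

The change from compound 3 brings in a six-membered ring, a ring nitrogen and a methoxy group all at once, and the compounds shown do not separate these parts. Open, as far as these compounds go, is whether a plain pyridin-4-yl group or a methoxyphenyl group would stay within the scatter of compound 3 or follow compound 4, and whether an amino group in place of the methoxy group would shift the number at all.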